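This account rests on a few compounds, and the source may have more. Where it says the series, first, only, none or still open, it means among the compounds named here.

Measured so far in a functional assay on MDA-MB-231 cells (Homo sapiens) for cytotoxicity, read by MTT assay, with a stated time of 24 h; on this read-out lower numbers stand for stronger inhibition and higher numbers for weaker inhibition:
Compound 1 `C=C1C(=O)[C@H]2C[C@@H]1CC1=C2[C@]2(C)CCC[C@](C)(CO)[C@H]2CC1` gives only a limit, > 50000 nM.
Compound 2 `C[C@@H]1C(=O)[C@H]2C[C@]1(O)CC1=C2[C@]2(C)CCC[C@](C)(CO)[C@H]2CC1` gives only a limit, > 50000 nM.
Compound 3 `C[C@@H]1C(=O)[C@H]2C[C@]1(O)CC1=C2[C@]2(C)CCCC(C)(C)[C@H]2CC1` gives only a limit, > 50000 nM.

Compound 2 thus stands at the limit where all three shown values sit, as the limit of > 50000 nM in this assay, at which 3 of the 3 values shown sit, records; no number has been read for it. Compound 4 `C[C@@H]1C(=O)[C@H]2C[C@]1(O)CC1=C2[C@]2(C)CCC[C@](C)(C=O)[C@H]2CC1` differs from compound 2 by formyl in place of hydroxymethyl on a saturated ring carbon. For the measured compounds named here, the only measured step that touches compound 2, a step that the two limits leave unreadable from compound 2 to compound 3, runs between two limits and has no readable size, so it says nothing about the change to a formyl. With every value at the limit and no readable step, no change is expected in this assay beyond the scatter. The expected step is a step that the limit leaves unreadable from compound 2 to compound 4. Compound 4 is estimated at 60000 nM, within 20000 nM to 200000 nM.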

Compound 4, half-maximal inhibitory concentration: > 50000 nM
Compound 4: no number, only a limit; the forecaster's own chance of this, stated with the estimate: 80%; the middle value lies beyond the limit too.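

Compound 2 and compound 4 both give only a limit, so no size can be read for the change from hydroxymethyl to formyl: the limit of > 50000 nM in this assay, at which 4 of the 4 values shown sit.

The compounds shown leave open what change to the shared core, if any, would give an actual number in this assay.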